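From methoxy to trifluoromethyl on the shared core

The source may hold more compounds than are shown below. What is called first, only, known or untested is meant among the compounds shown, and "the series" means these compounds.

Compound 3 (`COc1ccc2[nH]c(-c3cn(-c4ccccc4)nc3-c3ccc(F)cc3)nc2c1`) reads > 50000 nM in an ADME assay on HaCaT cells (Homo sapiens) for cytotoxicity, read by MTT assay, with a stated time of 48 h (on this read-out higher numbers stand for weaker inhibition and lower numbers for stronger inhibition), and that is a limit, not a number. Compound 2 (`Fc1ccc(-c2nn(-c3ccccc3)cc2-c2nc3ccccc3[nH]2)cc1`) reads > 50000 nM and that too is a limit. Among the measured compounds shown here, the one measured step is a step that the two limits leave unreadable from compound 2 to compound 3 and gives no size to build on. Compound 4 (`Fc1ccc(-c2nn(-c3ccccc3)cc2-c2nc3cc(C(F)(F)F)ccc3[nH]2)cc1`) differs from compound 3 by trifluoromethyl in place of methoxy on an aromatic carbon and so has trifluoromethyl in place of methoxy on an aromatic carbon. Compound 1 (`FC(F)(F)c1ccc2[nH]c(-c3cn(-c4ccccc4)nc3-c3ccccc3)nc2c1`) also carries trifluoromethyl and reads 37200 nM as a true number, so compound 4 is expected to give a number near it. For compound 4 a limit remains possible. The expected change is an at least 1.4-fold lower number from compound 3 to compound 4 (0.15 log units; that floor lies within the scatter) towards stronger inhibition, with its size uncertain. Compound 4 is expected at 35000 nM with 15000 nM to 70000 nM as the estimated range.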

Compound 4, half-maximal inhibitory concentration: > 50000 nM
Compound 4 was reported as a limit (the forecaster's own chance of this, stated with the estimate: 35%); middle value at least 1.4-fold (0.15 log units) away from the limit.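

In this assay, trifluoromethyl in place of methoxy on this aromatic carbon leaves compound 4 at a limit, so the steps joining compound 2, compound 3 and compound 4 cannot be read. Trifluoromethyl at this position therefore does not by itself give a true number. Among the compounds shown here, the one readable step is an at least 1.3-fold higher number from compound 1 to compound 4 (0.12 log units; that floor lies within the scatter), with fluoro in place of hydrogen on an aromatic carbon, and it shows no change beyond the scatter. As far as these compounds go, how an amine or a carboxylic acid on this carbon would read stays open, as does whether any group here would leave the shared limit: the limit of > 50000 nM in this assay, at which 3 of the 4 values shown sit.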